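The compounds below may be only part of what the source reports. "The series", "measured", "known", "first", "only" and "open" are said of these compounds alone.

Going by the values given here, two compounds share one core, and only two numbers are known so far. Compound 1 `NC(=O)c1csc(N2CCC(Oc3ccccc3C(F)(F)F)CC2)n1` and compound 2 `Cc1nnc(-c2cnc(N3CCC(Oc4ccccc4C(F)(F)F)CC3)s2)s1` were both tested in an assay on microsomes from liver (strain Wistar) for inhibition of acyl-CoA desaturase 1 (Rattus norvegicus), read by HPLC, with stated times of 1 h and 60 min; on this read-out lower numbers stand for stronger inhibition and higher numbers for weaker inhibition. Compound 1 gives 676 nM in this assay. Compound 2 gives 750 nM in this assay, the higher of the two numbers, but the gap to compound 1 lies within the usual scatter of repeated measurements, so the two compounds cannot be told apart on these data.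

Compound 3 `OCc1nc(-c2cnc(N3CCC(Oc4ccccc4C(F)(F)F)CC3)s2)no1` has not yet been measured. It differs from compound 2 in one place: 5-(hydroxymethyl)-1,2,4-oxadiazol-3-yl in place of 5-methyl-1,3,4-thiadiazol-2-yl on an aromatic carbon. Among the compounds with values here, no measured pair of compounds shows this exact change, so no measured step exists to anchor the expectation. What the data do show is that compound 1 and compound 2, which differ from each other only in this same place, return numbers close to one another. On that basis the step from compound 2 to compound 3 in this assay is expected to be a 1.2-fold lower number from compound 2 to compound 3 (0.06 log units; within the scatter), no larger than the scatter, in either direction. Compound 3 is therefore expected to give about 650 nM in this assay, with a range from 220 nM to 2000 nM.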

Compound 3, half-maximal inhibitory concentration: 1 nM
Estimate against measurement, compound 3: 650-fold (2.81 log units) above, and the stated range ends above it.
By their numbers in this assay, from the lowest: compound 3; then compounds 1 and 2 (each within the scatter of the next).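

In this assay, the group on this aromatic carbon, next to the ring sulfur, can decide nearly everything: replacing 5-methyl-1,3,4-thiadiazol-2-yl with 5-(hydroxymethyl)-1,2,4-oxadiazol-3-yl gives a 750-fold lower number from compound 2 to compound 3 (2.88 log units; beyond the scatter), even though both groups are five-membered aromatic rings with 3 hetero atoms. Compound 1 and compound 2 sat within the scatter of each other, so those two compounds alone gave no sign that this place could matter so much; that closeness now holds only for their two groups and not for the position as a whole. Nothing shown here gives a measured reason for the size of this step.

The change alters the ring and adds a hydroxymethyl group at once, so the compounds shown leave open which of the two carries the step, a question that 5-methyl-1,2,4-oxadiazol-3-yl at this carbon would address by differing from compound 3 only in the hydroxyl. Also open, from the compounds shown here alone, is what happens when the hydroxymethyl gives way to a longer chain such as hydroxyethyl, to an amine such as aminomethyl, or to a carboxylic acid.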